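Ethoxycarbonyl to carboxy: the step from compound 2

The source may hold more compounds than are shown below. What is called first, only, known or untested is meant among the compounds shown, and "the series" means these compounds.

In a functional assay on ECV-304 cells (Homo sapiens) for cytotoxicity, read by MTT assay, with stated times of 24 h and 12 h (a lower number here means that less compound is needed, a higher number that more compound is needed for the effect), compound 1 (`CCOC(=O)/C=C/c1ccccc1OCc1nc(C)c(C)nc1C`) gives 1540000 nM and compound 2 (`CCOC(=O)/C=C/c1cc(Br)cc(Br)c1OCc1nc(C)c(C)nc1C`) gives 1590000 nM so these two values lie within the scatter of each other. Compound 3 (`COc1cc(/C=C/C(=O)O)cc(OC)c1OCc1nc(C)c(C)nc1C`) gives 3530000 nM in this assay and so stands above compound 2 by more than the scatter. Compound 2 therefore sits level with compound 1 and beneath compound 3 on the numbers available.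

Compound 4 (`Cc1nc(C)c(COc2c(Br)cc(Br)cc2/C=C/C(=O)O)nc1C`) follows from compound 2 by one change (hydrogen in place of ethyl on an oxygen next to a carbonyl group) with hydrogen in place of ethyl on an oxygen next to a carbonyl group, which reads as ethoxycarbonyl to carboxy. For the measured compounds named here, no pair of measured compounds shows this change alone. Going by the values given here, the only hint is that compound 3, the one measured compound carrying carboxy, gives 3530000 nM as its reading, although its core also differs from that of compound 2. A modest move toward a higher number is therefore expected, with the expected step being a 1.6-fold higher number from compound 2 to compound 4 (0.20 log units; within the scatter) and not clearly beyond the scatter. For compound 4 the estimate is 2500000 nM with 1200000 nM to 5000000 nM as the expected range.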

Compound 4, half-maximal effective concentration: 1970000 nM
The estimate for compound 4 lay 1.3-fold (0.10 log units) above the measured number; the range from low to high includes it.
By their numbers in this assay, from the lowest: compounds 1, 2, 4 and 3 (each within the scatter of the next, the first and the last beyond it).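

In this assay, hydrogen takes the place of ethyl on an oxygen next to a carbonyl group with nothing else altered, and the outcome is a 1.2-fold higher number from compound 2 to compound 4 (0.09 log units; within the scatter), so this exchange of ethoxycarbonyl for carboxy does not move the reading beyond the scatter on the core of compound 2. The earlier compounds shown here could not show this, since compound 3 was the only one carrying carboxy and its core also differs from that of compound 2, which left the effect of this change alone unread. Nothing measured here explains why the reading holds through this change.

Going by these compounds, what an amide or a methyl ester would give at this place remains open, as does the outcome for a longer chain such as butyl in place of the ethyl. On these data alone, it also remains open whether ethoxycarbonyl to carboxy would read the same way on the core of compound 1 or on that of compound 3, so the present result stands for the core of compound 2 alone.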